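Swapping the Oxane for an Oxetane Ether

This account rests on a few compounds, and the source may have more. Where it says the series, first, only, none or still open, it means among the compounds named here.

Among the compounds with values here, compound 1 `Cc1nc(C)n(CC(=O)N2CCN(c3sc(C(F)(F)F)nc3-c3nc4ccc(C5CCOCC5)cc4[nH]3)C[C@H]2C)n1` is one of two compounds measured in a functional assay on Venous blood for antagonist activity at C-X-C chemokine receptor type 3 (Homo sapiens), read by flow cytometry, with a stated time of 30 min, in the presence of a further agent that is not named here; on this read-out lower numbers stand for stronger inhibition and higher numbers for weaker inhibition. In this assay compound 1 gives 123 nM, the lowest of the two numbers. Compound 2 `C[C@@H]1CN(c2sc(C(F)(F)F)nc2-c2nc3ccccc3[nH]2)CCN1C(=O)CN1CCC(F)(F)CC1` differs from compound 1 in several places. In this assay compound 2 gives 2430 nM, a number well above that of compound 1 and beyond the usual scatter. Compound 3 `Cc1nc(C)n(CC(=O)N2CCN(c3sc(C(F)(F)F)nc3-c3nc4ccc(OC5COC5)cc4[nH]3)C[C@H]2C)n1` has not yet been measured. It differs from compound 1 by a single change: (oxetan-3-yl)oxy in place of oxan-4-yl on an aromatic carbon. Within the data shown here, no step between measured compounds that differ in one place exists to calibrate this exchange, so the expectation rests on compound 1 alone. The step of a 1.3-fold higher number from compound 1 to compound 3 (0.11 log units; within the scatter) is expected to be small, within the usual scatter or only slightly beyond it, in either direction. Compound 3 is accordingly estimated at 160 nM, with a range from 50 nM to 500 nM.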

Compound 3, half-maximal inhibitory concentration: 1480 nM
For compound 3 the middle estimate is 9.3-fold (0.97 log units) below the measured one, outside the stated range (above it).
By their numbers in this assay, from the lowest: compound 1; then compounds 3 and 2 (each within the scatter of the next).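

In this assay, the exchange of oxan-4-yl for (oxetan-3-yl)oxy on this aromatic carbon gives a 12-fold higher number from compound 1 to compound 3 (1.08 log units; beyond the scatter), so the position is sensitive to this change in the core of compound 1. The exchange replaces a six-membered ring of 6 heavy atoms and 1 hydrogen-bond acceptor with a four-membered ring in a group of 5 heavy atoms and 2 hydrogen-bond acceptors, and it also adds an oxygen on the aromatic carbon. No measurement here identifies which of these differences accounts for the step.

The compounds shown leave open whether the ring size or the ether oxygen governs the step, a question that oxetan-3-yl placed directly on the aromatic carbon or (oxan-4-yl)oxy could address. They also leave open how this position would respond to a basic amine such as piperidin-4-yl.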